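Ether chain replaced by methylsulfanyl on the pyrazolidinone core

The source may hold more compounds than are shown below. What is called first, only, known or untested is meant among the compounds shown, and "the series" means these compounds.

Compound 1 `CCCOCC1CN(c2ccccc2)NC1=O`: 1.95
Compound 2 `COCCOCC1CN(c2ccccc2)NC1=O`: 0.955
Compound 3 `CCOCCC1CN(c2ccccc2)NC1=O`: 1.06

In a physicochemical assay for lipophilicity (on this read-out lower numbers stand for lower lipophilicity and higher numbers for higher lipophilicity), compound 1 stands highest of the three measured compounds; compound 3 lies nearest, and compound 2 furthest below it. Compound 4 `CSC1CN(c2ccccc2)NC1=O` differs from compound 1 in one place: methylsulfanyl in place of propoxymethyl on a saturated ring carbon. The measured steps, a number 1.00 log units lower from compound 1 to compound 2 (beyond the scatter) and a number 0.89 log units lower from compound 1 to compound 3 (beyond the scatter), both keep an oxygen chain and only lengthen or rearrange it, while the step of a number 0.11 log units higher from compound 2 to compound 3 (within the scatter) stays within the scatter. None of them replaces an ether chain by a sulfur group, so they bear on the change only loosely. Compound 4 sheds most of the chain carbons, and a modest fall in this assay is expected, a number 0.45 log units lower from compound 1 to compound 4 (beyond the scatter). Compound 4 is therefore estimated at 1.5, with a range from 1 to 2.1.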

Compound 4, partition coefficient: 1.97
The estimate for compound 4 lay 0.47 log units below the measured number; low and high end bracket the measured number.
By their numbers in this assay, from the lowest: compounds 2 and 3 (each within the scatter of the next); then compounds 1 and 4 (each within the scatter of the next).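

In this assay the step of a number 0.02 log units higher from compound 1 to compound 4 (within the scatter) shows that methylsulfanyl, with 2 heavy atoms, stands level with the 5 heavy atoms of propoxymethyl on this saturated ring carbon. The steps of a number 0.91 log units higher from compound 3 to compound 4 (beyond the scatter) and a number 1.02 log units higher from compound 2 to compound 4 (beyond the scatter) show that it does not stand level with the 2-ethoxyethyl or (2-methoxyethoxy)methyl groups. No evidence at hand accounts for this result. The compounds shown leave open whether a longer sulfur chain such as propylsulfanyl, a methoxy group or an amine on this ring carbon would stay level with compound 1.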